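Nitro for Cyano on a Shared Anilide Core

The compounds below may be only part of what the source reports. "The series", "measured", "known", "first", "only" and "open" are said of these compounds alone.

Measured so far in a functional assay on CWR22R cells (Homo sapiens) for antiproliferative activity, read by fluorescence and propidium iodide staining, with a stated time of 96 h; a lower number here means a stronger inhibitor, a higher number a weaker inhibitor:
Compound 1, `CC(O)(CSc1cc(C(F)(F)F)cc(C(F)(F)F)c1)C(=O)Nc1ccc(C#N)cc1C(F)(F)F`, gives 4650 nM.
Compound 2, `CC(O)(CSc1cc(C(F)(F)F)cc(C(F)(F)F)c1)C(=O)Nc1ccc([N+](=O)[O-])cc1C(F)(F)F`, gives 2290 nM.
Compound 3, `CC(O)(COc1cc(C(F)(F)F)cc(C(F)(F)F)c1)C(=O)Nc1ccc(C#N)cc1C(F)(F)F`, gives 4070 nM.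

Compound 1 and compound 2 differ by one change, (nitro in place of cyano on an aromatic carbon), and that change brought a 2.0-fold lower number from compound 1 to compound 2 (0.31 log units; beyond the scatter). Compound 3 shares the anilide end with compound 1 but differs in the linker; the difference between the two cores is not broken down here. Compound 4, `CC(O)(COc1cc(C(F)(F)F)cc(C(F)(F)F)c1)C(=O)Nc1ccc([N+](=O)[O-])cc1C(F)(F)F`, is not yet measured; it carries the same change relative to compound 3, (nitro in place of cyano on an aromatic carbon), at an identical place. Because compound 1 to compound 2 gave a 2.0-fold lower number from compound 1 to compound 2 (0.31 log units; beyond the scatter), a comparable step is expected from compound 3 to compound 4, a 2.0-fold lower number from compound 3 to compound 4 (0.31 log units; beyond the scatter), although a single earlier example leaves the size uncertain. Compound 4 is therefore estimated at 2000 nM in this assay, within 1000 nM to 4000 nM.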

Compound 4, half-maximal inhibitory concentration: 16100 nM
For compound 4 the middle estimate is 8.1-fold (0.91 log units) below the measured one; the whole stated range lies below it.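

In this assay, putting nitro in place of cyano on the second core gave a 4.0-fold higher number from compound 3 to compound 4 (0.60 log units; beyond the scatter), the opposite direction to the step seen on the first core. The two results differ by more than repeat measurements would explain: the same change on two cores in this assay, a 2.0-fold lower number (0.31 log units; beyond the scatter) from compound 1 to compound 2 and a 4.0-fold higher number (0.60 log units; beyond the scatter) from compound 3 to compound 4, 8.0-fold (0.90 log units) apart, beyond the scatter of two such steps. So, for these two cores, the outcome of this change depends on the core that carries it, but two examples cannot show which feature of the cores is responsible or how a further core would respond.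

As far as these compounds go, it remains open whether an amine or a carboxylic acid in the same place would also behave differently on the two cores. From the compounds shown here alone, it is also open how nitro and cyano would compare with a longer chain as the linker.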